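A few compounds are considered here, and "the series" means these few. Any claim that something is new, unique, unknown or untested is made for them only; others in the source may bear on it.

Among the three compounds measured so far, compound 3 `CCN1CCN(c2cc(C)c3cc(NC(=O)c4ccc(Cl)cc4)ccc3n2)CC1` holds the lowest number: in a functional assay on SK-BR-3 cells (Homo sapiens) for antiproliferative activity, read by MTT assay, with a stated time of 72 h (a lower number here means a stronger inhibitor, a higher number a weaker inhibitor), compound 3 gives 3020 nM. Compound 1 `CCN1CCN(c2cc(C)c3cc(NC(=O)c4cccc(Cl)c4)ccc3n2)CC1` gives 17800 nM, and compound 2 `CCN(CC)c1cc(C)c2cc(NC(=O)c3ccc(Cl)c(Cl)c3)ccc2n1` gives 41200 nM, the highest of the three. Among the measured compounds shown here, the one clean step among them, a 5.9-fold lower number from compound 1 to compound 3 (0.77 log units; beyond the scatter), shows that moving the chloro from the 3-position to the 4-position of the phenyl ring lowers the number.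

Compound 4 `CCN1CCN(c2cc(C)c3cc(NC(=O)c4ccc(Cl)c(Cl)c4)ccc3n2)CC1` keeps the 4-chloro and adds a second one: chloro in place of hydrogen on an aromatic carbon. For the measured compounds named here, no measured step adds a chloro directly; compound 2 also carries the 3,4-dichlorophenyl but differs from compound 3 in more than one place, so its high number is only a hint. Given that the 3-chloro alone was the weaker placement in a 5.9-fold lower number from compound 1 to compound 3 (0.77 log units; beyond the scatter), a small step toward a higher number, or none beyond the scatter, is expected. Compound 4 is therefore estimated at 5500 nM, within 1800 nM to 18000 nM. That estimate implies an expected step of a 1.8-fold higher number from compound 3 to compound 4 (0.26 log units; within the scatter).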

Compound 4, half-maximal inhibitory concentration: 2160 nM
For compound 4 the middle estimate is 2.5-fold (0.41 log units) above the measured one; measured number inside the range.
By their numbers in this assay, from the lowest: compounds 4 and 3 (each within the scatter of the next); then compound 1; then compound 2.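

In this assay, the step for chloro in place of hydrogen on the 4-chlorophenyl is a 1.4-fold lower number from compound 3 to compound 4 (0.15 log units; within the scatter) and so cannot be told apart from no change, which means this ring position tolerates a chloro when the 4-chloro is already present. The same 3,4-dichlorophenyl compared with the 3-chlorophenyl gives an 8.2-fold lower number from compound 1 to compound 4 (0.92 log units; beyond the scatter) and, unlike the first step, lies beyond the scatter, so the 4-chloro still counts when a 3-chloro is present. With the 3,4-dichlorophenyl held fixed, 4-ethylpiperazin-1-yl in place of diethylamino gives a 19-fold lower number from compound 2 to compound 4 (1.28 log units; beyond the scatter) and is the largest step here, showing that the amine on the core matters more than the added chloro.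

No measurement here explains any of these steps. Still open, from the compounds shown here alone, is whether a methyl or methoxy at this ring position would behave like the chloro, and whether a longer chain in place of the ethyl on the piperazine would keep these numbers.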